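Ethoxycarbonyl to Methoxycarbonyl: a Forecast for Compound 4

The source may hold more compounds than are shown below. What is called first, only, known or untested is meant among the compounds shown, and "the series" means these compounds.

In an ADME assay on WI-38 cells (Homo sapiens) for inhibition, read by CellTiter-Glo, with a stated time of 48 h, tested at 100 uM (on this read-out higher numbers stand for more inhibition at the one concentration tested (going by the name of the read-out) and lower numbers for less inhibition), the three measured compounds stand as follows:
compound 1 `CCOC(=O)/C=C/NC(=O)[C@H](O)C(C)(C)CO` gives 36%
compound 2 `CCOC(=O)/C=C\NC(=O)[C@H](O)C(C)(C)CO` gives 1%
compound 3 `CCOC(=O)/C=C\NC(=O)[C@@H](O)C(C)(C)CO` gives -6%

Compound 1 stands highest of the three. The step of a number 35 percentage points lower from compound 1 to compound 2 (beyond the scatter) and the step of a number 42 percentage points lower from compound 1 to compound 3 (beyond the scatter) are both large, and in each case the two compounds differ in nothing but the drawn configuration the fact that compounds 1 and 2 differ only in the configuration as drawn (the fact that compounds 1 and 3 differ only in the configuration as drawn). The step of a number 7 percentage points lower from compound 2 to compound 3 (within the scatter) lies within the scatter, again with only the configuration differing (the fact that compounds 2 and 3 differ only in the configuration as drawn).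

Compound 4 `COC(=O)/C=C/NC(=O)[C@H](O)C(C)(C)CO` keeps the configuration of compound 1 at both stereo elements and differs from it in one place: hydrogen in place of methyl on a saturated chain carbon bound to an oxygen next to a carbonyl group. For the measured compounds named here, none of the measured steps touches the ethoxycarbonyl group; each of them changes configuration alone, so none of them speaks directly to the ethyl-to-methyl change. The large falls seen on going to the Z-drawn double bond do not apply, since compound 4 shares the E-drawn double bond of compound 1. Going by the values given here, with no step of the same kind to lean on, compound 4 is expected to sit close to compound 1, with a step of a number 4 percentage points lower from compound 1 to compound 4 (within the scatter) that is expected to stay within the scatter. The estimate for compound 4 in this assay is 32%, with a range from 12% to 52%.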

Compound 4, a percentage reported as inhibition, at one concentration (the size of the read-out at that concentration, not a potency): 4%
Compound 4: middle estimate off by 28 percentage points, on the high side, outside the stated range (below it).
By their numbers in this assay, from the lowest: compounds 3, 2 and 4 (each within the scatter of the next); then compound 1.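

The ethoxycarbonyl group turns out not to be a silent part of compound 1: in this assay, ethoxycarbonyl to methoxycarbonyl, with both stereo elements left as they are, gives a number 32 percentage points lower from compound 1 to compound 4 (beyond the scatter). The earlier steps shown here changed configuration alone, so they could only tie the high number of compound 1 to how the compound is drawn, whereas this step shows that the E-drawn double bond and the drawn stereocentre do not by themselves hold that number up, and that the single methyl on the carbon bound to the ester oxygen counts as well. The compounds shown offer nothing that accounts for this step, as their only other differences lie in configuration and say nothing about an ethyl-to-methyl change.

From the compounds shown here alone, what a longer chain, such as propyl or butyl, would give in place of the ethyl remains open, and so does the outcome with a carboxylic acid in place of the ester. Going by these compounds, it is also open whether ethyl to methyl would have any comparable effect on the Z-drawn double bond, where the numbers already stand low.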